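Amide in place of acid on an inactive pyridine scaffold

A few compounds are considered here, and "the series" means these few. Any claim that something is new, unique, unknown or untested is made for them only; others in the source may bear on it.

Compound 1, `O=C(O)/C=C/c1ccncc1-c1ccc2cc[nH]c2c1`: in a functional assay on KB cells (Homo sapiens) for inhibition, read by sulforhodamine B assay, with a stated time of 72 h (on this read-out higher numbers stand for weaker inhibition of growth and lower numbers for stronger inhibition of growth), compound 1 gives > 10000 nM, which is a limit of the assay.
Compound 2, `CNC(=O)/C=C/c1ccncc1-c1ccc2c(cnn2C)c1`: in this assay compound 2 gives > 10000 nM, again a limit.
Compound 3, `NNC(=O)CCc1ccncc1-c1ccc2ccccc2c1`: in this assay compound 3 gives > 10000 nM, also a limit.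

Compound 1 thus stands at the limit of > 10000 nM in this assay, at which 3 of the 3 values shown sit; no number separates it from the others. Compound 4, `CNC(=O)/C=C/c1ccncc1-c1ccc2cc[nH]c2c1`, differs from compound 1 by methylamino in place of hydroxy on a carbonyl carbon. Within the data shown here, since every value shown is a limit, no measured step exists to lean on, and no direction can be read from the data. The expectation is that the change from compound 1 to compound 4 amounts to a step that the limit leaves unreadable from compound 1 to compound 4, nothing beyond the scatter. Compound 4 is estimated at 15000 nM, within 5000 nM to 50000 nM, most likely reported as a limit again.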

Compound 4, concentration for 50% growth inhibition: > 10000 nM
Compound 4 gave a limit, no number (the forecaster's own chance of this, stated with the estimate: 85%); the middle value does not contradict the limit.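

No step can be read between compound 1 and compound 4, since both values are limits and not numbers: the limit of > 10000 nM in this assay, at which 4 of the 4 values shown sit.

The compounds shown leave open whether methylamino in place of hydroxy on a carbonyl carbon changes inhibition of growth at all in this assay.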